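This account rests on a few compounds, and the source may have more. Where it says the series, first, only, none or still open, it means among the compounds named here.

Measured in a functional assay on A549 cells (Homo sapiens) for antiproliferative activity, read by MTT assay, with a stated time of 48 h; on this read-out higher numbers stand for weaker inhibition and lower numbers for stronger inhibition:
- compound 1 `Cc1cc(C(=O)N2CCC3(CC2)CC(=O)N(c2ccc(C(F)(F)F)cc2)C3)cc2cn[nH]c12`: > 10000 nM (a limit of the assay, not a number)
- compound 2 `O=C(c1ccc2[nH]c(-c3ccccc3)nc2c1)N1CCC2(CC1)CC(=O)N(c1ccc(C(F)(F)F)cc1)C2`: 1920 nM
- compound 3 `CC(C)c1ccc(-c2nc3cc(C(=O)N4CCC5(CC4)CC(=O)N(c4ccc(C(F)(F)F)cc4)C5)ccc3[nH]2)cc1`: 1030 nM

Compound 3 stands level with compound 2 on these numbers, and the two values lie within the scatter of each other. The third reading, that of compound 1, is only a limit, so it gives no exact comparison.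

Compound 4 `O=C(c1ccc2[nH]c(-c3ccncc3)nc2c1)N1CCC2(CC1)CC(=O)N(c1ccc(C(F)(F)F)cc1)C2` has pyridin-4-yl in place of the 4-isopropylphenyl of compound 3, on an aromatic carbon of a five-membered aromatic ring with 2 nitrogen, between two ring nitrogen atoms (pyridin-4-yl in place of 4-isopropylphenyl on an aromatic carbon). Among the measured compounds shown here, the only measured step on this aryl group is a 1.9-fold lower number from compound 2 to compound 3 (0.27 log units; within the scatter), an isopropyl in place of hydrogen on an aromatic carbon, and it lies within the scatter. Losing the isopropyl of compound 3 is therefore expected to cost little. For the measured compounds named here, no measured step shows what a ring nitrogen does here, so the expectation stays wide and leans only slightly towards a higher number in this assay. The expected change is a 1.9-fold higher number from compound 3 to compound 4 (0.29 log units; within the scatter), which is no clear step beyond the scatter. For compound 4 the estimated value is 2000 nM, with an expected range of 700 nM to 6000 nM.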

Compound 4, half-maximal inhibitory concentration: 3490 nM
Compound 4: the middle estimate sits 1.7-fold (0.24 log units) below what was measured, within the range that was stated.
By their numbers in this assay, from the lowest: compounds 3, 2 and 4 (each within the scatter of the next, the first and the last beyond it). At a limit, above all of these: compound 1.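

In the assay (this assay), a change of the aryl group on the aromatic carbon between two ring nitrogen atoms now gives a step beyond the scatter, though a modest one, with pyridin-4-yl in place of 4-isopropylphenyl (a 3.4-fold higher number from compound 3 to compound 4 (0.53 log units; beyond the scatter)). Set against the plain phenyl, pyridin-4-yl gives no step that clears the scatter (a 1.8-fold higher number from compound 2 to compound 4 (0.26 log units; within the scatter)), so the ring nitrogen alone shows no clear effect at this position, and only the two end members of the series, compound 3 and compound 4, stand apart, with compound 2 within the scatter of each. Nothing measured here accounts for the difference between compound 3 and compound 4.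

The compounds shown leave open how pyridin-3-yl or pyridin-2-yl would read at this carbon, and so whether the place of the ring nitrogen matters. They also leave open what an amine, a carboxylic acid or a longer alkyl chain in place of the isopropyl on the phenyl ring would do in this series.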